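The source may report more compounds than this note shows. Statements on the series, on what has been measured and on what is new or still open speak of the compounds shown alone.

Compound 1 `Cc1ccc(C)n1-c1ccc2c(c1)C(n1ccccc1=O)=CC(C)(C)O2`: 7.27
Compound 2 `CC1(C)C=C(n2ccccc2=O)c2cc(OS(=O)(=O)F)ccc2O1`: 7.95
Compound 3 `CC1(C)C=C(n2ccccc2=O)c2cc(C#N)ccc2O1`: 7.67

In a functional assay (aorta) with Rattus norvegicus as the target (a higher number here means a more potent compound, by a factor of ten per unit of this negative logarithm, a lower number a less potent compound), compound 3 sits between the other two: the gap from compound 2 is a number 0.28 log units lower from compound 2 to compound 3 (within the scatter), while the rise a number 0.40 log units higher from compound 1 to compound 3 (beyond the scatter) is clear. Compound 4 `CC1(C)C=C(n2ccccc2=O)c2cc(Br)ccc2O1` differs from compound 3 by bromo in place of cyano on an aromatic carbon. Among the measured compounds shown here, two measured steps touch the cyano group, a number 0.40 log units higher from compound 1 to compound 3 (beyond the scatter) and a number 0.28 log units lower from compound 2 to compound 3 (within the scatter), but none of them brings in a bromo group, so they can only frame the question. The two small substituents at this aromatic carbon gave numbers close to each other, so the exchange of cyano for bromo is expected to move this assay little, if at all beyond the scatter. Compound 4 is therefore estimated at 7.6, between 7.1 and 8.1. The expected step is a number 0.07 log units lower from compound 3 to compound 4 (within the scatter).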

Compound 4, logarithm of the reciprocal of the active concentration, log(1/C): 7.84
Compound 4: middle estimate off by 0.24 log units, on the low side, within the range that was stated.
By their numbers in this assay, from the lowest: compound 1; then compounds 3, 4 and 2 (each within the scatter of the next).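

In this assay, bromo on this aromatic carbon cannot be told apart from the two earlier small groups, with a number 0.17 log units higher from compound 3 to compound 4 (within the scatter) against cyano and a number 0.11 log units lower from compound 2 to compound 4 (within the scatter) against (fluorosulfonyl)oxy. The 2,5-dimethyl-1H-pyrrol-1-yl group alone remains separate, and a number 0.57 log units higher from compound 1 to compound 4 (beyond the scatter) shows that bromo, like those two groups, gives a clear step from it. Nothing measured here accounts for this grouping. The compounds shown leave open how an amine, a carboxylic acid or a longer alkyl chain on this carbon would read.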